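Removing a Nitro Group on a Weakly Active Series

This account rests on a few compounds, and the source may have more. Where it says the series, first, only, none or still open, it means among the compounds named here.

Compound 1 `O=[N+]([O-])c1ccc(COc2ccc(Nc3ncnc4cc5c(cc34)OCCOCCO5)cc2)cc1` and compound 2 `c1ccc(COc2ccc(Nc3ncnc4cc5c(cc34)OCCOCCO5)cc2)cc1` share one core and differ by hydrogen in place of nitro on an aromatic carbon. In a functional assay on SH-SY5Y cells (Homo sapiens) for antiproliferative activity, read by MTT assay, with a stated time of 72 h (a higher number here means a weaker inhibitor, a lower number a stronger inhibitor), compound 1 gives 55200 nM. In this assay compound 2 gives 39300 nM. Together these give a 1.4-fold lower number from compound 1 to compound 2 (0.15 log units; within the scatter). Compound 3 `O=[N+]([O-])c1ccc(COc2ccc(Nc3ncnc4cc5c(cc34)OCCOCCOCCOCCO5)cc2)cc1` is built on a different core; the difference between the two cores is not broken down here. In this assay compound 3 shows only a limit, > 100000 nM, which is the limit of > 100000 nM in this assay, at which 1 of the 3 values shown sits. Compound 4 `c1ccc(COc2ccc(Nc3ncnc4cc5c(cc34)OCCOCCOCCOCCO5)cc2)cc1` differs from compound 3 by hydrogen in place of nitro on an aromatic carbon, the same change as that between compound 1 and compound 2. Since the earlier step was a 1.4-fold lower number from compound 1 to compound 2 (0.15 log units; within the scatter), the expected step is a number no higher from compound 3 to compound 4 (the limit leaves the size open). Compound 4 is therefore estimated at 100000 nM, somewhere from 50000 nM to 300000 nM, and may well again be reported only as a limit.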

Compound 4, half-maximal inhibitory concentration: 5250 nM
The estimate for compound 4 lay 19-fold (1.28 log units) above the measured number, and the stated range ends above it.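

Carried to the other core, hydrogen in place of nitro gives an at least 19-fold lower number from compound 3 to compound 4 (1.27 log units; beyond the scatter) in this assay. From the compounds shown here alone, the value of compound 3, > 100000 nM, is a limit of the assay and not a number, so the full size of this step stays open. The size of the change therefore does not carry over from one core to the other, although these two pairs do not show why: the same change on two cores in this assay, a 1.4-fold lower number (0.15 log units; within the scatter) from compound 1 to compound 2 and an at least 19-fold lower number (1.27 log units; beyond the scatter) from compound 3 to compound 4, at least 13-fold (1.13 log units) apart, beyond the scatter of two such steps

For the compounds shown here, with only two pairs, it remains open how this change would behave on any further core. Going by these compounds, it also remains open how an amine or a carboxylic acid in place of the nitro group would read on either core.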